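Methyl to Ethyl on the Ring Amine of Compound 1

The compounds below may be only part of what the source reports. "The series", "measured", "known", "first", "only" and "open" are said of these compounds alone.

Compound 1 `COc1ccc(/C=C2\CN(C)CC3C2=NN(c2nc(-c4ccc(Cl)cc4)cs2)C3c2ccc(OC)cc2)cc1` and compound 2 `COc1cc(/C=C2\CCCc3c2nc(N)c(C#N)c3-c2ccc(O)c(OC)c2)ccc1O` are the two compounds measured in a functional assay on Ehrlich cells (Mus musculus) for cytotoxicity, read by trypan blue exclusion, with a stated time of 24 h, tested at 100 uM; on this read-out higher numbers stand for a stronger effect at the one concentration tested and lower numbers for a weaker effect. Compound 1 gives 97.9% in this assay, the lower of the two numbers, while compound 2 gives 99.7% in this assay, and the two values lie within the scatter of each other. Compound 3 `CCN1C/C(=C\c2ccc(OC)cc2)C2=NN(c3nc(-c4ccc(Cl)cc4)cs3)C(c3ccc(OC)cc3)C2C1` differs from compound 1 by methyl in place of hydrogen on a saturated chain carbon bound to an amine nitrogen in a ring. Among the measured compounds shown here, with no step between measured compounds to draw on and both measured numbers close to complete activity, no change beyond the scatter is expected, and the expected step reads a number 1.9 percentage points lower from compound 1 to compound 3 (within the scatter). Compound 3 is therefore estimated at 96%, within 85% to 100%.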

Compound 3, a percentage reported as activity, at one concentration (the size of the read-out at that concentration, not a potency): 100%
For compound 3 the middle estimate is 4 percentage points below the measured one, within the range that was stated.
By their numbers in this assay, from the lowest: compounds 1, 2 and 3 (each within the scatter of the next).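

The step reads a number 2.1 percentage points higher from compound 1 to compound 3 (within the scatter) in this assay, so at this position on the saturated chain carbon bound to the ring amine nitrogen, the change from methyl to ethyl moves the read-out by no more than the scatter. With compound 1 already at 97.9%, the read-out has little room left to show a gain. Nothing measured here offers an explanation for this result.

Going by these compounds, whether a longer chain such as propyl, or a benzyl group, on the ring amine would also hold the read-out remains open. So does any difference among these compounds at lower concentrations.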